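This account rests on a few compounds, and the source may have more. Where it says the series, first, only, none or still open, it means among the compounds named here.

Measured so far:
compound 1, `COc1ccc(-c2cnc3nc(N)nc(N4CCC(C)CC4)c3n2)cc1OC` — 800 nM
compound 2, `COc1ccc(-c2cnc3nc(N)nc(N4CCN(C(=O)c5ccccc5)CC4)c3n2)cc1OC` — 400 nM

Compound 1 `COc1ccc(-c2cnc3nc(N)nc(N4CCC(C)CC4)c3n2)cc1OC` and compound 2 `COc1ccc(-c2cnc3nc(N)nc(N4CCN(C(=O)c5ccccc5)CC4)c3n2)cc1OC` share a core and were both examined in a functional assay on cells (T-cell, Homo sapiens) for inhibition; a higher number here means a weaker inhibitor, a lower number a stronger inhibitor. In this assay compound 1 gives 800 nM, and compound 2 gives 400 nM. These two values lie within the usual scatter of each other, so compound 2 cannot be set apart from compound 1 on the numbers shown; it simply stands alongside it.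

Compound 3 `COc1ccc(-c2cnc3nc(N)nc(N4CCN(C(=O)NCc5ccccc5)CC4)c3n2)cc1OC` has not yet been measured. It differs from compound 2 in one place: benzylamino in place of phenyl on a carbonyl carbon. Within the data shown here, no step between measured compounds speaks to this kind of change, so the only guide is the value of compound 2 itself. With the carbonyl on the ring nitrogen kept, the expectation is a step of no change at the digits printed from compound 2 to compound 3 (within the scatter), that is, none beyond the scatter in either direction. On that basis compound 3 is expected to give about 400 nM in this assay, with a range from 150 nM to 1000 nM.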

Compound 3, half-maximal inhibitory concentration: 18 nM
Compound 3: middle estimate off by 22-fold (1.35 log units), on the high side, outside the stated range (below it).
By their numbers in this assay, from the lowest: compound 3; then compounds 2 and 1 (each within the scatter of the next).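

In this assay, benzylamino in place of phenyl on a carbonyl carbon gives a 22-fold lower number from compound 2 to compound 3 (1.35 log units; beyond the scatter) and so shows that this position is far from indifferent to what is attached there, even with the carbonyl on the ring nitrogen kept. Both groups carry one six-membered aromatic ring of carbon only, so the step comes with that ring retained, while the entering group brings a nitrogen and a hydrogen-bond donor that phenyl lacks. Nothing available bears on why the number moves so far.

The compounds shown do not separate the contribution of the nitrogen from that of the longer link to the ring. Open, therefore, is how a benzyl group, with carbon in place of that nitrogen, or an anilino group, with the methylene removed, would compare on the same carbonyl carbon.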